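Methoxycarbonyl Replaces Hydrogen on a Core Held at the Limit

This account rests on a few compounds, and the source may have more. Where it says the series, first, only, none or still open, it means among the compounds named here.

Compound 1 `CCn1nc(C)cc1C(=O)Nc1nc2cc(C(N)=O)cc(OC)c2n1CCCNC(=O)OCc1ccccc1`: > 100000 nM
Compound 2 `CCCn1c(NC(=O)c2cc(C)nn2CC)nc2cc(C(=O)OC)cc(OC)c21`: > 100000 nM
Compound 3 `CCn1nc(C)cc1C(=O)Nc1nc2cccc(OC)c2n1CCCNC(=O)OCc1ccccc1`: > 100000 nM

Three compounds share the core of compound 3. In an assay for activation of interferon regulatory factor 3 (Homo sapiens), read by a luciferase reporter, with a stated time of 20 h (on this read-out higher numbers stand for an effect only at larger amounts of compound and lower numbers for an effect already at smaller amounts), compound 3 gives only a limit of the assay, > 100000 nM. Compound 1, which carries a carbamoyl group on the same aromatic carbon, likewise gives only a limit, > 100000 nM. Compound 2, which carries a methoxycarbonyl group there but a different chain on the ring nitrogen, also gives only a limit, > 100000 nM. Going by the values given here, the one step that joins measured compounds, a step that the two limits leave unreadable from compound 1 to compound 3, cannot be read, as the limit of > 100000 nM in this assay, at which 3 of the 3 values shown sit, holds all three values.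

Compound 4 `CCn1nc(C)cc1C(=O)Nc1nc2cc(C(=O)OC)cc(OC)c2n1CCCNC(=O)OCc1ccccc1` differs from compound 3 in one place: methoxycarbonyl in place of hydrogen on an aromatic carbon. No readable step bears on this change, and compound 2 with the same group sits at the limit. The step of a number no higher from compound 3 to compound 4 (the limit leaves the size open) is therefore expected to stay within the scatter, with compound 4 most likely again at the limit. For compound 4 in this assay the estimate is 100000 nM, between 30000 nM and 300000 nM.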

Compound 4, half-maximal effective concentration: 27600 nM
Estimate against measurement, compound 4: 3.6-fold (0.56 log units) above, and the stated range ends above it.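

In this assay, going by these compounds alone, methoxycarbonyl on this aromatic carbon gives the first readable step, an at least 3.6-fold lower number from compound 3 to compound 4 (0.55 log units; beyond the scatter). The group's presence is not enough on its own: methoxy on the carbonyl carbon counts, as the amide partner shows with an at least 3.6-fold lower number from compound 1 to compound 4 (0.55 log units; beyond the scatter), and the chain counts too, as the (benzyloxycarbonyl)amino group shows with an at least 3.6-fold lower number from compound 2 to compound 4 (0.55 log units; beyond the scatter). All three sizes remain open-ended, since each partner sits at the same limit: the limit of > 100000 nM in this assay, at which 3 of the 4 values shown sit.

The compounds shown leave open whether the lower number belongs to the methyl ester itself or would also appear with an ethyl ester, a carboxylic acid or a nitrile on this carbon. From the compounds shown here alone, it also remains open how much of the chain is needed, for instance whether a free amine at its end would serve.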